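Restoring an Aromatic Ring on the Ring Nitrogen

The compounds below may be only part of what the source reports. "The series", "measured", "known", "first", "only" and "open" are said of these compounds alone.

Of the compounds shown here, two have been measured in a functional assay on MG-63 cells (Homo sapiens) for inhibition, read by CCK-8 assay, with a stated time of 72 h, tested at 1 uM; on this read-out lower numbers stand for less inhibition and higher numbers for more inhibition at the one concentration tested (going by the name of the read-out). Compound 1 `COc1ccc(OC)c(N2C(=O)CSC2c2cccc(C(=O)NCCCCc3ccccc3)c2)c1` gives 92% in this assay, and compound 2 `CCN1C(=O)CSC1c1cccc(C(=O)NCCCCc2ccccc2)c1` gives 0%. Among the measured compounds shown here, compound 2 therefore stands lowest of the two numbers, with compound 1 its only neighbour and far above it. For the measured compounds named here, the single step measured so far, a number 92 percentage points lower from compound 1 to compound 2 (beyond the scatter), shows that replacing the aromatic group on an amide-type nitrogen in a ring with ethyl removes essentially all inhibition. Compound 3 `O=C(NCCCCc1ccccc1)c1cccc(C2SCC(=O)N2c2ccccc2F)c1` has not yet been measured; it differs from compound 2 by 2-fluorophenyl in place of ethyl on an amide-type nitrogen in a ring. This change runs the earlier step backwards in kind, putting an aromatic ring back on the same nitrogen, though 2-fluorophenyl rather than 2,5-dimethoxyphenyl. Because the step of a number 92 percentage points lower from compound 1 to compound 2 (beyond the scatter) was large, a large rise is expected here, a number 70 percentage points higher from compound 2 to compound 3 (beyond the scatter), with the different ring leaving room for a partial recovery. Compound 3 is expected to give 70%, within a range from 35% to 95%.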

Compound 3, a percentage reported as inhibition, at one concentration (the size of the read-out at that concentration, not a potency): 92%
For compound 3 the middle estimate is 22 percentage points below the measured one; measured number inside the range.
By their numbers in this assay, from the lowest: compound 2; then compounds 1 and 3 (each within the scatter of the next).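

Putting an aromatic ring back on the ring nitrogen restores the inhibition in full, with a number 92 percentage points higher from compound 2 to compound 3 (beyond the scatter), so ethyl is the outlier among the three groups at this position. The two aromatic groups cannot be told apart here, with no change at the digits printed from compound 1 to compound 3 (within the scatter), which shows that the 2,5-dimethoxyphenyl pattern of compound 1 is not required for a high reading, since 2-fluorophenyl serves equally well. No measurement is available to explain why the aromatic groups and ethyl differ so sharply.

Going by these compounds, it remains open whether this nitrogen needs an aromatic ring at all, or whether a saturated cyclohexyl ring or a longer chain such as hexyl would also give a high reading. Readings at a single concentration also leave open whether compound 1 and compound 3 differ in potency.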